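The source may hold more compounds than are shown below. What is called first, only, known or untested is meant among the compounds shown, and "the series" means these compounds.

Of the compounds shown here, three sharing one core have been tested in an ADME assay on microsomes from liver (Homo sapiens) for metabolic stability, with a stated time of 10 min; on this read-out lower numbers stand for a less stable compound and higher numbers for a more stable compound. Compound 1 `O=C(NS(=O)(=O)c1ccc(F)cc1)c1ccc(Nc2nc(NC3(c4ccc(Cl)cc4)CC3)nc(OCC(F)(F)F)n2)cc1` gives 100%, compound 2 `CC(C)NCCS(=O)(=O)NC(=O)c1ccc(Nc2nc(NC3(c4ccc(Cl)cc4)CC3)nc(OCC(F)(F)F)n2)cc1` gives 89%, and compound 3 `CCS(=O)(=O)NC(=O)c1ccc(Nc2nc(NC3(c4ccc(Cl)cc4)CC3)nc(OCC(F)(F)F)n2)cc1` gives 100%. Among the compounds with values here, compound 3 stands level with compound 1 at the top of the three, while the only step beyond the scatter is a number 11 percentage points higher from compound 2 to compound 3 (beyond the scatter). Compound 4 `CC(C)OC(=O)NCCS(=O)(=O)NC(=O)c1ccc(Nc2nc(NC3(c4ccc(Cl)cc4)CC3)nc(OCC(F)(F)F)n2)cc1` differs from compound 3 by (isopropoxycarbonyl)amino in place of hydrogen on a saturated chain carbon, two bonds along the chain from a sulfonyl sulfur. Within the data shown here, one measured step concerns that same chain carbon: a number 11 percentage points higher from compound 2 to compound 3 (beyond the scatter). There, removing a substituent raised the number modestly, so adding a substituent at the same place is expected to lower it modestly or leave it within the scatter. For compound 4 the estimate is 92%, with a range from 78% to 100%. The expected step is a number 8 percentage points lower from compound 3 to compound 4 (within the scatter).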

Compound 4, percent of the compound remaining: 100%
Compound 4: the middle estimate sits 8 percentage points below what was measured, within the range that was stated.
By their numbers in this assay, from the lowest: compound 2; then compounds 1, 3 and 4 (each within the scatter of the next).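

In this assay, (isopropoxycarbonyl)amino on this chain carbon gives no change at the digits printed from compound 3 to compound 4 (within the scatter), so this large substituent is tolerated here, which the isopropylamino chain did not show. Isopropoxycarbonyl in place of isopropyl on the amine nitrogen gives a number 11 percentage points higher from compound 2 to compound 4 (beyond the scatter), so the number depends on what sits on that nitrogen, not just on the chain. The 2-((isopropoxycarbonyl)amino)ethyl group also matches 4-fluorophenyl on the sulfonyl sulfur, with no change at the digits printed from compound 1 to compound 4 (within the scatter) as the step. No evidence here explains these results. On these data alone, how an unsubstituted amine, a carboxylic acid or a longer chain would behave at this place remains open.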